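A Trifluoromethyl Added to the Best of Three Amides

The source may report more compounds than this note shows. Statements on the series, on what has been measured and on what is new or still open speak of the compounds shown alone.

Compound 1, `O=C(NCc1ccco1)c1ccccc1OCc1ccccc1`: 49000 nM in an assay on lysate for inhibition of phosphatidylcholine:ceramide cholinephosphotransferase 2 (Homo sapiens), read by HPLC, with stated times of 30 min and 2 h; on this read-out lower numbers stand for stronger inhibition and higher numbers for weaker inhibition
Compound 2, `O=C(Nc1ccccn1)c1ccccc1OCc1ccccc1`: 11700 nM
Compound 3, `O=C(Nc1cccnc1)c1ccccc1OCc1ccccc1`: 3200 nM

All three share one core and differ only in the group on the amide-type nitrogen. Compound 3 stands lowest of the three numbers: the change a 3.7-fold lower number from compound 2 to compound 3 (0.56 log units; beyond the scatter) and the change a 15-fold lower number from compound 1 to compound 3 (1.19 log units; beyond the scatter) both lie beyond the scatter, so compound 3 is the strongest inhibitor measured here.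

Compound 4, `O=C(Nc1cccnc1)c1ccccc1OCc1ccccc1C(F)(F)F`, keeps the nitrogen substituent of compound 3 and changes a different part of the molecule: trifluoromethyl in place of hydrogen on an aromatic carbon. Among the compounds with values here, none of the measured steps touches this ring; the steps of a 4.2-fold lower number from compound 1 to compound 2 (0.62 log units; beyond the scatter), a 15-fold lower number from compound 1 to compound 3 (1.19 log units; beyond the scatter) and a 3.7-fold lower number from compound 2 to compound 3 (0.56 log units; beyond the scatter) all concern the amide nitrogen only, so they give no direct guide. With nothing to point either way, the expected step of a 1.3-fold lower number from compound 3 to compound 4 (0.11 log units; within the scatter) is small, and compound 4 is estimated at 2500 nM, with a range from 700 nM to 9000 nM.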

Compound 4, half-maximal inhibitory concentration: 2100 nM
Beside the measured number, compound 4's estimate is 1.2-fold (0.08 log units) above it, within the range that was stated.
By their numbers in this assay, from the lowest: compounds 4 and 3 (each within the scatter of the next); then compound 2; then compound 1.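

Within the data shown here, the earlier compounds differed only at the amide-type nitrogen, so compound 4 gives the first look at another part of the molecule: an aromatic carbon of a six-membered aromatic ring of carbon only, ortho to a large group. In this assay, trifluoromethyl in place of hydrogen at this place gives a 1.5-fold lower number from compound 3 to compound 4 (0.18 log units; within the scatter), so adding these 4 heavy atoms leaves the number indistinguishable from that of compound 3, unlike the change at the nitrogen in a 3.7-fold lower number from compound 2 to compound 3 (0.56 log units; beyond the scatter). No accompanying measurement bears on what lies behind this result.

From the compounds shown here alone, whether a smaller or different group here, such as a chlorine atom, a methoxy group or an amine, would move the number beyond the scatter remains open. So does whether trifluoromethyl would give a similar result on another carbon of this ring.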